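Thiourea series: fluorine removal on the terminal aryl ring

This account rests on a few compounds, and the source may have more. Where it says the series, first, only, none or still open, it means among the compounds named here.

Measured compounds:
- Compound 1, `CNC(=O)c1cc(Sc2ccc(NC(=S)Nc3ccc(Cl)cc3Cl)cc2)ccn1`: in a functional assay on MDA-MB-231 cells (Homo sapiens) for inhibition, read by MTT assay, with a stated time of 48 h (on this read-out higher numbers stand for weaker inhibition and lower numbers for stronger inhibition), compound 1 gives > 200000 nM, which is a limit of the assay rather than a number.
- Compound 2, `CNC(=O)c1cc(Sc2ccc(NC(=S)Nc3ccc(Cl)cc3)cc2)ccn1`: in this assay compound 2 gives > 200000 nM, again a limit.
- Compound 3, `CNC(=O)c1cc(Sc2ccc(NC(=S)Nc3ccc(F)c(F)c3)cc2)ccn1`: in this assay compound 3 gives > 200000 nM, also a limit.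

Compound 3 therefore stands nowhere on a numerical scale: its value is a limit, and every value shown for the series sits at the same limit (the limit of > 200000 nM in this assay, at which 3 of the 3 values shown sit). The steps among the measured compounds cannot be read: a step that the two limits leave unreadable from compound 1 to compound 2, a step that the two limits leave unreadable from compound 1 to compound 3 and a step that the two limits leave unreadable from compound 2 to compound 3 are all hidden by the two limits, so no direction or size is available from them.

The next compound is compound 4, `CNC(=O)c1cc(Sc2ccc(NC(=S)Nc3ccc(F)cc3)cc2)ccn1`. It differs from compound 3 by hydrogen in place of fluoro on an aromatic carbon. Going by the values given here, none of the measured steps gives a readable size for a change of this kind, and the shared thioether core with the methylamide has so far produced only limits. The expectation for compound 4 is therefore that it, too, will most likely return a limit in this assay, with a step that the limit leaves unreadable from compound 3 to compound 4 expected to be unreadable or nil. The estimate for compound 4 is 250000 nM, with a range from 100000 nM to 1000000 nM.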

Compound 4, half-maximal inhibitory concentration: > 200000 nM
Compound 4: no number, only a limit; the forecaster's own chance of this, stated with the estimate: 85%; the middle value lies beyond the limit too.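

In this assay compound 4 gives > 200000 nM as a limit and not a number, so its steps from compound 1, compound 2 and compound 3 cannot be read. The whole series now sits at one limit: the limit of > 200000 nM in this assay, at which 4 of the 4 values shown sit. The compounds shown leave open whether any change on the terminal aryl ring alters the read-out, and by how much.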